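Hydrazone aryl series: removing the hydroxy of compound 1

The source may report more compounds than this note shows. Statements on the series, on what has been measured and on what is new or still open speak of the compounds shown alone.

Measured compounds:
- compound 1 `Cn1c(=O)c(=O)n(C2CCCC2)c2nc(N/N=C/c3cc(C(F)(F)F)c(O)c(C(F)(F)F)c3)ncc21`: 17700 nM
- compound 2 `Cn1c(=O)c(=O)n(C2CCCC2)c2nc(N/N=C/c3ccco3)ncc21`: 72200 nM
- compound 3 `Cn1c(=O)c(=O)n(C2CCCC2)c2nc(N/N=C/c3ccc(F)cc3Cl)ncc21`: 15200 nM

In a functional assay on PC-3 cells (Homo sapiens) for antiproliferative activity, read by MTT assay (on this read-out lower numbers stand for stronger inhibition and higher numbers for weaker inhibition), compound 1 gives 17700 nM, the second highest of the three numbers. Compound 3 gives 15200 nM, and the two values lie within the scatter of each other. Compound 2 gives 72200 nM, a higher number than that of compound 1 and beyond the scatter.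

The unmeasured compound 4 `Cn1c(=O)c(=O)n(C2CCCC2)c2nc(N/N=C/c3cc(C(F)(F)F)cc(C(F)(F)F)c3)ncc21` differs from compound 1 in one place: hydrogen in place of hydroxy on an aromatic carbon of a six-membered aromatic ring of carbon only, ortho to two trifluoromethyl groups and para to a large group.

Going by the values given here, the only measured step, a 4.8-fold lower number from compound 2 to compound 3 (0.68 log units; beyond the scatter), exchanges the whole ring on the carbon with a double bond to nitrogen and does not isolate a hydroxy. Among the compounds with values here, no measured pair tests a hydroxy on its own, so the direction of the change is open. Given that compound 1 and compound 3 sit within the scatter of each other in this assay despite different substitution, a small shift is expected; the step is estimated at a 1.1-fold higher number from compound 1 to compound 4 (0.05 log units; within the scatter), not beyond the scatter. Compound 4 is therefore expected to give about 20000 nM, with a range of 8000 nM to 50000 nM.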

Compound 4, half-maximal inhibitory concentration: 8200 nM
For compound 4 the middle estimate is 2.4-fold (0.39 log units) above the measured one; measured number inside the range.
By their numbers in this assay, from the lowest: compounds 4, 3 and 1 (each within the scatter of the next, the first and the last beyond it); then compound 2.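

In this assay, the hydroxy on the aromatic carbon ortho to two trifluoromethyl groups and para to a large group proves dispensable: replacing it with hydrogen gives a 2.2-fold lower number from compound 1 to compound 4 (0.33 log units; beyond the scatter) and so moves the number in the direction of stronger inhibition, although the step is modest. Going by these compounds alone, this is the first step confined to a single substituent on the ring, whereas the earlier step exchanged the whole ring, so it shows that the hydroxy and its hydrogen-bond donor and acceptor are not required for activity at this position and that the two trifluoromethyl groups alone, on this ring, suffice to retain it. Nothing measured here accounts for the step, which stands as an observation only.

The compounds shown leave open whether another group at this position, such as a methoxy, an amine or a carboxylic acid, would follow hydrogen or hydroxy. They also leave open what each trifluoromethyl group contributes and whether removing a hydroxy has a similar effect on other aromatic rings attached to the shared core.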